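This account rests on a few compounds, and the source may have more. Where it says the series, first, only, none or still open, it means among the compounds named here.

Within the data shown here, in an in vitro ADME assay on microsomes from liver (Homo sapiens) for pharmacokinetics (on this read-out higher numbers stand for fast clearance and lower numbers for slow clearance), compound 1 `Cc1ccc(S(=O)(=O)N2C=CNC(=O)[C@H]2CC(=O)N[C@H]2CCN(CC(C)C)CC2(C)C)cc1` gives 27 mL.min-1.g-1, the only firm number so far. Compound 2 `CC1(C)CNCC[C@@H]1NC(=O)C[C@@H]1C(=O)NC=CN1S(=O)(=O)c1ccc(Cl)c(Cl)c1` is reported only as a limit of the assay, < 50 mL.min-1.g-1, and not as a number. That reading is the limit of < 50 mL.min-1.g-1 in this assay, at which 1 of the 2 values shown sits. Compound 3 `Cc1cc(S(=O)(=O)N2C=CNC(=O)[C@H]2CC(=O)N[C@H]2CCNCC2(C)C)c(C)cc1Cl` keeps the core and the amine side of compound 2 and changes only the aryl group: 4-chloro-2,5-dimethylphenyl stands in place of 3,4-dichlorophenyl on a sulfonyl sulfur, (4-chloro-2,5-dimethylphenyl in place of 3,4-dichlorophenyl on a sulfonyl sulfur). Among the measured compounds shown here, no measured step shows what such an exchange does in this assay, so no large change is expected, and the expected step, a step that the limit leaves unreadable from compound 2 to compound 3, is an estimate that starts from a limit. The expectation therefore leans on compound 1 at 27 mL.min-1.g-1. For compound 3, the estimated clearance is 30 mL.min-1.g-1, with an expected range from 12 mL.min-1.g-1 to 65 mL.min-1.g-1.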

Compound 3, intrinsic clearance in microsomes: 21 mL.min-1.g-1
For compound 3 the middle estimate is 1.4-fold (0.15 log units) above the measured one; the measured number falls inside the stated range.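

No step from compound 2 to compound 3 can be read in this assay, because the value of compound 2 is a limit and not a number: the limit of < 50 mL.min-1.g-1 in this assay, at which 1 of the 3 values shown sits.

The compounds shown leave open what 4-chloro-2,5-dimethylphenyl in place of 3,4-dichlorophenyl on a sulfonyl sulfur does to clearance.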